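The source may report more compounds than this note shows. Statements on the series, on what has been measured and on what is new or still open speak of the compounds shown alone.

Compound 1 `CC(CCNC(=O)c1c(Cl)cncc1Cl)N1CCC(C(Oc2ccccc2C(F)(F)F)c2ccc(C(F)(F)F)cc2)CC1`: in an ADME assay on PBMC cells (Homo sapiens) for cytotoxicity (a higher number here means that more compound is tolerated, a lower number that less compound is tolerated), compound 1 gives 12500 nM.
Compound 2 `CC(CCNC(=O)c1c(Cl)cncc1Cl)N1CCC(C(Oc2cccc(Cl)n2)c2ccc(C(F)(F)F)cc2)CC1`: in this assay compound 2 gives > 32500 nM, which is a limit of the assay and not a number.

Compound 2 therefore stands at the limit, as the limit of > 32500 nM in this assay, at which 1 of the 2 values shown sits, records, so only a floor for its value is known. Going by the values given here, the one measured step, an at least 2.6-fold higher number from compound 1 to compound 2 (0.41 log units; beyond the scatter), concerns the group on an oxygen on a saturated carbon and moved the value up to that limit.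

Compound 3 `CC(CCNC(=O)c1c(Cl)cncc1Cl)N1CCC(C(Oc2cccc(Cl)n2)c2ccc(OC(F)(F)F)cc2)CC1` differs from compound 2 in another place: trifluoromethoxy in place of trifluoromethyl on an aromatic carbon. Among the compounds with values here, no measured step touches that position, so the step to compound 3 cannot be read from the data; compound 2 already sits at the limit, and the change is small. Compound 3 is therefore expected to remain near the limit, with a number no higher from compound 2 to compound 3 (the limit leaves the size open). The estimate for compound 3 in this assay is 32500 nM, within 15000 nM to 65000 nM.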

Compound 3, half-maximal cytotoxic concentration: 6000 nM
Beside the measured number, compound 3's estimate is 5.4-fold (0.73 log units) above it, and the stated range ends above it.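

In this assay, trifluoromethoxy in place of trifluoromethyl on the aromatic carbon para to a large group gives an at least 5.4-fold lower number from compound 2 to compound 3 (0.73 log units; beyond the scatter). Going by these compounds alone, this position, which no earlier step touched, therefore matters for how much compound the cells tolerate, even though the swap looks small on paper. Compound 2 carries a limit of the assay and not a number, so this step fixes only the smallest size the change can have: the limit of > 32500 nM in this assay, at which 1 of the 3 values shown sits.

Within the data shown here, only one pair tests this swap, so it stays open whether the same fall would appear with the 2-(trifluoromethyl)phenyl group of compound 1 on the oxygen. The compounds shown also leave open how an amine, a carboxylic acid or a simple methoxy group at this position would behave in this assay.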